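Series notes: oxygen for nitrogen on the shared core

A few compounds are considered here, and "the series" means these few. Any claim that something is new, unique, unknown or untested is made for them only; others in the source may bear on it.

Three compounds share a core carrying a carbamoyl group and a 2-ethylbutyl side chain. Compound 1 `CCC(CC)CNc1c(C(N)=O)cnc2ccc(C#N)cc12` gives 820 nM in an assay on HT-29 cells for inhibition of Serine-protein kinase ATM (Homo sapiens), read by fluorescence, with a stated time of 1 h; on this read-out higher numbers stand for weaker inhibition and lower numbers for stronger inhibition. Compound 2 `CCC(CC)CNc1c(C(N)=O)cnc2ccc(-c3cccnc3)cc12` gives 73 nM in this assay, and compound 3 `CCC(CC)CNc1c(C(N)=O)cnc2ccc(-c3ccc(CS(C)(=O)=O)nc3)cc12` gives 39 nM in this assay. The step of an 11-fold lower number from compound 1 to compound 2 (1.05 log units; beyond the scatter) is large, whereas the step of a 1.9-fold lower number from compound 2 to compound 3 (0.27 log units; within the scatter) stays within the scatter. Compound 2 thus stands second highest of the three numbers, with compound 3 nearest and compound 1 furthest.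

Compound 4 `CCC(CC)COc1c(C(N)=O)cnc2ccc(-c3cccnc3)cc12` differs from compound 2 by 2-ethylbutoxy in place of (2-ethylbutyl)amino on an aromatic carbon. Within the data shown here, neither measured step touches this position: both concern the other end of the core, so no measured step bears on the change. The data offer no guide for the exchange of the donor-bearing group for an ether here, and the expectation rests on compound 2 alone. For compound 4 in this assay the estimate is 220 nM, with a range from 50 nM to 1000 nM. The corresponding step of a 3.0-fold higher number from compound 2 to compound 4 (0.48 log units; beyond the scatter) is expected to be modest and uncertain in direction.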

Compound 4, half-maximal inhibitory concentration: > 30000 nM
Compound 4: only a limit was reported (the forecaster's own chance of this, stated with the estimate: 5%); at least 130-fold (2.13 log units) between middle value and limit.
By their numbers in this assay, from the lowest: compounds 3 and 2 (each within the scatter of the next); then compound 1. At a limit, above all of these: compound 4.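

This position tolerates the change far less than the estimate's single reference point suggested: in this assay, replacing (2-ethylbutyl)amino with 2-ethylbutoxy, on the carbon ortho to a carbamoyl group, gives an at least 410-fold higher number from compound 2 to compound 4 (2.61 log units; beyond the scatter). The entering and leaving groups both have 7 heavy atoms, but (2-ethylbutyl)amino has 1 hydrogen-bond donor and 2-ethylbutoxy has 0, so a swap of one atom in the chain is enough to separate compound 4 from all three earlier compounds, which varied only the other end of the core. The result for compound 4 is a limit, not a number: the limit of > 30000 nM in this assay, at which 1 of the 4 values shown sits.

Going by these compounds, whether the donor itself or some other difference between nitrogen and oxygen drives this remains open, and a thioether or an N-methyl amine at this place would help separate the two. Also open, on these data alone, is whether the same exchange behaves alike with the (methylsulfonyl)methyl group of compound 3 in place.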